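Lipophilicity notes on a dibromophenyl imidazoline amine series

The compounds below may be only part of what the source reports. "The series", "measured", "known", "first", "only" and "open" are said of these compounds alone.

Measured so far:
Compound 1 `Brc1cccc(Br)c1N(CC1CC1)C1=NCCN1` gives -1.12 in a physicochemical assay for lipophilicity; on this read-out higher numbers stand for higher lipophilicity and lower numbers for lower lipophilicity.
Compound 2 `Brc1ccc(N(CC2CC2)C2=NCCN2)c(Br)c1` gives -0.31 in this assay.
Compound 3 `CC(C)CCN(C1=NCCN1)c1c(Br)cccc1Br` gives 0.16 in this assay.

Compound 3 stands highest of the three numbers in this assay; compound 2 lies nearest, and compound 1 furthest, both gaps beyond the scatter. The next compound, compound 4 `Brc1cccc(Br)c1N(CC1CCCCC1)C1=NCCN1`, is not yet measured in this assay. Against compound 3 it differs in one place: cyclohexyl in place of isobutyl on a saturated chain carbon bound to a nitrogen on an aromatic ring.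

Among the compounds with values here, one measured step bears on this change, the one from compound 1 to compound 3, where the saturated chain carbon bound to the nitrogen carried isobutyl in place of cyclopropyl and this assay moved by a number 1.28 log units higher from compound 1 to compound 3 (beyond the scatter). Cyclohexyl brings six carbons in a ring where isobutyl brought four, so a further rise in this assay is expected for compound 4, though somewhat smaller than that earlier step because a number 1.28 log units higher from compound 1 to compound 3 (beyond the scatter) already spans a larger change in carbon count. The expected step is a number 0.70 log units higher from compound 3 to compound 4 (beyond the scatter). Compound 4 is therefore estimated at 0.86, with a range from 0.4 to 1.3.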

Compound 4, distribution coefficient: 0.27
Beside the measured number, compound 4's estimate is 0.59 log units above it; measured number below the stated range.
By their numbers in this assay, from the lowest: compound 1; then compound 2; then compounds 3 and 4 (each within the scatter of the next).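

At this place, on a saturated chain carbon bound to a nitrogen on an aromatic ring, this assay gives a number 0.11 log units higher from compound 3 to compound 4 (within the scatter) for cyclohexyl in place of isobutyl, so the ring and the larger carbon count leave the read-out within the scatter. Set against cyclopropyl, both groups give large steps, a number 1.28 log units higher from compound 1 to compound 3 (beyond the scatter) and a number 1.39 log units higher from compound 1 to compound 4 (beyond the scatter), so among these three groups the read-out does not follow carbon count throughout: cyclopropyl stands apart, while isobutyl and cyclohexyl stand together. No supporting data explain why these two groups read alike.

Going by these compounds, whether a longer chain, a phenyl group or an amine at this place would stay with isobutyl and cyclohexyl remains open. Also open, on these data alone, is whether the step from cyclopropyl to cyclohexyl would carry over to the core of compound 2.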